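Swapping a chlorophenyl-furan for a biphenyl on the amide

The source may report more compounds than this note shows. Statements on the series, on what has been measured and on what is new or still open speak of the compounds shown alone.

Compound 1, `COc1ccc(NCCNC(=O)[C@@H](NC(=O)c2cccc(C)c2)C2CCCCC2)cc1`, in an assay on isolated protein for inhibition of cathepsin S (Homo sapiens), at 37 degrees C, at pH 5.5 (a lower number here means a stronger inhibitor, a higher number a weaker inhibitor), compound 1 gives 23 nM.
Compound 2, `COc1ccc(NCCNC(=O)[C@H](CC2CCCCC2)NC(=O)c2ccc(-c3ccc(Cl)cc3)o2)cc1`, in this assay compound 2 gives 7.1 nM.
Compound 3, `COc1ccc(NCCNC(=O)[C@H](CC2CCCCC2)NC(=O)C2CCN(c3ncc(Br)cn3)CC2)cc1`, in this assay compound 3 gives 107 nM.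

Among these three numbers, compound 2 has the lowest; compound 1 sits at a higher number beyond the scatter, and compound 3 further still. Compound 4, `COc1ccc(NCCNC(=O)[C@H](CC2CCCCC2)NC(=O)c2cccc(-c3ccccc3)c2)cc1`, has not yet been measured. It differs from compound 2 in one place: 3-phenylphenyl in place of 5-(4-chlorophenyl)furan-2-yl on a carbonyl carbon. The attachment to the amide carbonyl is kept, and the size of the group is the same, but the ring with one oxygen is gone and, with it, the chlorine. Among the measured compounds shown here, compound 1 shows that a plain carbon-only aromatic ring on this carbonyl can still give a low number, though the two compounds also differ elsewhere, so no clean step can be drawn. The expectation is a small rise in number from compound 2 to compound 4, around a 2.1-fold higher number from compound 2 to compound 4 (0.32 log units; beyond the scatter), possibly no more than the scatter. Compound 4 is therefore estimated at 15 nM, between 4 nM and 60 nM.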

Compound 4, inhibition constant: 2.9 nM
The estimate for compound 4 lay 5.2-fold (0.71 log units) above the measured number; the measured number lies below the stated range.
By their numbers in this assay, from the lowest: compound 4; then compound 2; then compound 1; then compound 3.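

In this assay the swap on this carbonyl carbon gives a modest change (a 2.4-fold lower number from compound 2 to compound 4 (0.39 log units; beyond the scatter)), and the step lies beyond the scatter. The position therefore does not depend on the five-membered ring with its oxygen, or on the chlorine, to reach a low number: 3-phenylphenyl, built of carbon alone and with no hydrogen-bond acceptor, does better here than 5-(4-chlorophenyl)furan-2-yl. Nothing available accounts for this gain.

Going by these compounds, the ring and the chlorine change together in this single step, so their separate contributions remain unknown. Also open, on these data alone, is how the number would respond to a chlorine, an amine or a carboxylic acid placed on the 3-phenylphenyl group.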